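Extending a chlorophenyl group by a double-bonded chain

The compounds below may be only part of what the source reports. "The series", "measured", "known", "first", "only" and "open" are said of these compounds alone.

Compound 3 `COC(=O)/C=C/c1cccc(N(Cc2ccc(-c3cccc(Cl)c3)cc2)C(=O)C(C)C)c1` gives 77 nM in an assay on isolated protein with Bile acid receptor (Homo sapiens) as the target (a higher number here means that more compound is needed for the effect, a lower number that less compound is needed), the second highest of the three measured numbers. Compound 1 `COC(=O)/C=C/c1cccc(N(Cc2ccc(/C=C/c3cccc(F)c3)cc2)C(=O)C(C)C)c1` gives 71 nM and compound 2 `COC(=O)/C=C/c1cccc(N(Cc2ccc(/C=C/c3ccccn3)cc2)C(=O)C(C)C)c1` gives 310 nM. Compound 4 `COC(=O)/C=C/c1cccc(N(Cc2ccc(/C=C/c3cccc(Cl)c3)cc2)C(=O)C(C)C)c1` differs from compound 3 by 2-(3-chlorophenyl)ethenyl in place of 3-chlorophenyl on an aromatic carbon. From the compounds shown here alone, the closest measured step is the reverse kind of change, a 1.1-fold higher number from compound 1 to compound 3 (0.04 log units; within the scatter), which stayed within the scatter; only the fluorine-to-chlorine swap on the aromatic ring is untested, and the larger jump a 4.4-fold higher number from compound 1 to compound 2 (0.64 log units; beyond the scatter) concerns a different ring. The step of a 1.1-fold lower number from compound 3 to compound 4 (0.04 log units; within the scatter) is therefore expected to stay within the scatter, and compound 4 is estimated at 70 nM, with a likely range from 35 nM to 150 nM.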

Compound 4, half-maximal effective concentration: 164 nM
Beside the measured number, compound 4's estimate is 2.3-fold (0.37 log units) below it; measured number above the stated range.
By their numbers in this assay, from the lowest: compounds 1 and 3 (each within the scatter of the next); then compounds 4 and 2 (each within the scatter of the next).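

On the chain, the halogen matters: a 2.3-fold higher number from compound 1 to compound 4 (0.36 log units; beyond the scatter), so chloro does not simply stand in for fluoro at this ring. Adding the ethenyl link to the 3-chlorophenyl group also raises the number, giving a 2.1-fold higher number from compound 3 to compound 4 (0.33 log units; beyond the scatter), so the link is not neutral with chloro on the ring. Pyridin-2-yl no longer stands apart on this chain, as a 1.9-fold lower number from compound 2 to compound 4 (0.28 log units; within the scatter) stays within the scatter.

Nothing here gives a reason for these steps. Also open, from the compounds shown here alone, is how an amine or a methoxy group in place of the chloro would behave on the same ethenyl chain.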